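Styryl benzyl sulfones: hydroxy for cyano on the benzyl ring

This account rests on a few compounds, and the source may have more. Where it says the series, first, only, none or still open, it means among the compounds named here.

Three members of the series have been read in a functional assay on DU-145 cells (Homo sapiens) for antiproliferative activity, read by trypan blue exclusion; on this read-out higher numbers stand for weaker inhibition and lower numbers for stronger inhibition. Compound 1 `COc1ccc(/C=C/S(=O)(=O)Cc2ccc(OC)cc2)cc1` returns only a limit, > 20000 nM, and no number. Compound 2 `COc1cc(OC)c(/C=C/S(=O)(=O)Cc2ccc([N+](=O)[O-])cc2)c(OC)c1` gives 15000 nM. Compound 3 `COc1cc(OC)c(/C=C/S(=O)(=O)Cc2ccc(C#N)cc2)c(OC)c1` gives 7500 nM. Among the compounds with values here, the sole single-point step, a 2.0-fold lower number from compound 2 to compound 3 (0.30 log units; within the scatter), stays within the scatter, so compounds 2 and 3 read as alike. Compound 3 therefore holds the lowest of the two numbers, with compound 2 nearest, while compound 1 sits at the limit of > 20000 nM in this assay, at which 1 of the 3 values shown sits.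

Compound 4 `COc1cc(OC)c(/C=C/S(=O)(=O)Cc2ccc(O)cc2)c(OC)c1` differs from compound 3 by hydroxy in place of cyano on an aromatic carbon, the change sitting on an aromatic carbon of a six-membered aromatic ring of carbon only, para to a large group. Within the data shown here, no measured step exchanges cyano for hydroxy. Among the measured compounds shown here, the one step available, a 2.0-fold lower number from compound 2 to compound 3 (0.30 log units; within the scatter), swapped two groups at this same carbon without moving beyond the scatter, which gives no ground for a shift in this assay. The step from compound 3 to compound 4 is thus expected to be no change at the digits printed from compound 3 to compound 4 (within the scatter), within the scatter. Compound 4 is estimated at 7500 nM, with a range of 2500 nM to 25000 nM.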

Compound 4, half-maximal inhibitory concentration: 7500 nM
The estimate for compound 4 equals the measured number at the digits printed, within the range that was stated.
By their numbers in this assay, from the lowest: compounds 3, 4 and 2 (each within the scatter of the next). At a limit, above all of these: compound 1.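

In this assay hydroxy in place of cyano gives no change at the digits printed from compound 3 to compound 4 (within the scatter) and hydroxy in place of nitro gives a 2.0-fold lower number from compound 2 to compound 4 (0.30 log units; within the scatter) at the same aromatic carbon. Three groups have now been read at this carbon, para to a large group, and compounds 2, 3 and 4 all lie within the scatter of one another, even though hydroxy brings one hydrogen-bond donor and cyano brings none. The compounds shown offer no measured property that bears on this flat reading.

Open, as far as these compounds go, is whether an amine, a carboxylic acid or a longer chain at this carbon would stay within the same scatter of compounds 2, 3 and 4. Also open, from the compounds shown here alone, is whether this flat reading holds when the methoxy groups of the shared core are changed.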